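This account rests on a few compounds, and the source may have more. Where it says the series, first, only, none or still open, it means among the compounds named here.

Compound 2 `CCCCCCc1ccncc1C#Cc1cc(Cl)ccc1OCC(=O)O` gives the lowest of the two numbers in an assay on CHO cells for displacement of a labelled ligand from prostaglandin D2 receptor 2 (Homo sapiens), read by scintillation counting (a lower number here means a stronger inhibitor, a higher number a weaker inhibitor), at 43 nM; its nearest neighbour, compound 1 `O=C(O)COc1ccc(Cl)cc1C#Cc1ccc(Cl)s1`, gives 183 nM, a gap beyond the scatter. Compound 3 `O=C(O)COc1ccc(Cl)cc1C#Cc1cccnc1` differs from compound 2 by hydrogen in place of hexyl on an aromatic carbon. Among the compounds with values here, no step between measured compounds isolates this change, so the expectation rests on the loss of the six-carbon chain alone. Compound 3 is expected to lose potency, with a step estimated at a 5.8-fold higher number from compound 2 to compound 3 (0.76 log units; beyond the scatter). For compound 3 the estimated value is 250 nM, in a range from 60 nM to 1000 nM.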

Compound 3, inhibition constant: 117 nM
Estimate against measurement, compound 3: 2.1-fold (0.33 log units) above; the measured number falls inside the stated range.
By their numbers in this assay, from the lowest: compound 2; then compounds 3 and 1 (each within the scatter of the next).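

Hydrogen in place of hexyl gives a 2.7-fold higher number from compound 2 to compound 3 (0.43 log units; beyond the scatter) in this assay, so the chain adds potency at this position, yet much of the activity remains without it. Pyridin-3-yl in place of 5-chlorothiophen-2-yl gives a 1.6-fold lower number from compound 1 to compound 3 (0.19 log units; within the scatter), so this assay does not separate these two groups. Nothing measured here bears on the reason for either step. Open, on these data alone, is how potency follows chain length on this aromatic carbon, from a propyl chain to an octyl chain. Also open, as far as these compounds go, is whether an amine there would match hexyl.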